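This account rests on a few compounds, and the source may have more. Where it says the series, first, only, none or still open, it means among the compounds named here.

Measured so far in an assay on isolated protein for displacement of a labelled ligand from Apoptosis regulator Bcl-2 (Homo sapiens), read by fluorescence polarization; a lower number here means a stronger inhibitor, a higher number a weaker inhibitor:
compound 1 `CC1(C)CCN(c2ccc(C(=O)NS(=O)(=O)c3ccc(NC(C)(C)CSc4ccccc4)c([N+](=O)[O-])c3)cc2)CC1`, giving 67 nM
compound 2 `COC1(Cc2ccccc2Br)CCN(c2ccc(C(=O)NS(=O)(=O)c3ccc(N[C@H](CCN(C)C)CSc4ccccc4)c([N+](=O)[O-])c3)cc2)CC1`, giving 1.5 nM
compound 3 `CN(C)CC[C@H](CSc1ccccc1)Nc1ccc(S(=O)(=O)NC(=O)c2ccc(N3CCN(Cc4ccccc4)CC3)cc2)cc1[N+](=O)[O-]`, giving 39.8 nM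

Compound 3 holds the second highest of the three numbers in this assay. Its nearest neighbour is compound 1, and the two values lie within the usual scatter of repeated measurements, so nothing separates them. Compound 2 stands furthest from compound 3, with a lower number by a margin beyond the scatter; the two compounds differ in several places at once, so that gap cannot be tied to any single change.

Compound 4 `CN(C)CC[C@H](CSc1ccccc1)Nc1ccc(S(=O)(=O)NC(=O)c2ccc(N3CCN(Cc4ccccc4S(C)(=O)=O)CC3)cc2)cc1[N+](=O)[O-]` remains to be measured in this assay. It differs from compound 3 in one place: methylsulfonyl in place of hydrogen on an aromatic carbon. Going by the values given here, no pair of measured compounds shares this change, so the series offers no precedent for the size of the step. With nothing in the data pointing either way, the step from compound 3 to compound 4 is expected to stay within the scatter, a 1.2-fold lower number from compound 3 to compound 4 (0.09 log units; within the scatter). On that basis compound 4 is estimated at 32 nM in this assay, with a range from 8 nM to 130 nM, the width reflecting the absence of any comparable step.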

Compound 4, inhibition constant: 4.6 nM
Compound 4: middle estimate off by 7.0-fold (0.84 log units), on the high side, outside the stated range (below it).
By their numbers in this assay, from the lowest: compound 2; then compound 4; then compounds 3 and 1 (each within the scatter of the next).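

In this assay, going by these compounds alone, the change from benzyl to 2-(methylsulfonyl)benzyl gives an 8.7-fold lower number from compound 3 to compound 4 (0.94 log units; beyond the scatter) and is the first single-place step, which makes this aromatic carbon, ortho to a large group, the first position whose substitution can be read directly. The position is not indifferent to substitution: methylsulfonyl, with its 4 heavy atoms and no net charge, is tolerated there and goes with a stronger inhibitor, although one step sets no trend. No measurement at hand bears on why the step has this size.

Going by these compounds, whether the step belongs to methylsulfonyl itself or would appear with other groups on the same carbon remains open; a methoxy group, a nitrile or a fluorine atom there would help separate these, as would methylsulfonyl on another carbon of the same ring. Also open, on these data alone, is whether the same change would give a step of similar size on the differently substituted frameworks of compound 1 and compound 2.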